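This account rests on a few compounds, and the source may have more. Where it says the series, first, only, none or still open, it means among the compounds named here.

Series notes. Compound 3 `O=C(Oc1cccc(F)c1)c1cc2cc([N+](=O)[O-])ccc2oc1=O` gives 53.6% in a functional assay on HT-1080 cells (Homo sapiens), read by transwell migration, with a stated time of 24 h, tested at 1 uM (on this read-out lower numbers stand for a stronger effect and higher numbers for a weaker effect at the one concentration tested), the second highest of the three numbers; compound 2 `CC(=O)OCc1ccc2oc(=O)c(C(=O)N(C)c3cccc(Cl)c3)cc2c1` gives 82.6% and compound 1 `CC(=O)OCc1ccc2oc(=O)c(C(=O)Oc3cccc(Br)c3)cc2c1` gives 21.8%. Compound 4 `O=C(Oc1cccc(I)c1)c1cc2cc([N+](=O)[O-])ccc2oc1=O` differs from compound 3 by iodo in place of fluoro on an aromatic carbon. For the measured compounds named here, the only step between measured compounds, a number 60.8 percentage points higher from compound 1 to compound 2 (beyond the scatter), swaps the ester for an amide and does not bear on a halogen exchange. Compound 1 carries a bromo and compound 3 a fluoro on the phenoxy group, but they also differ on the core, so their values alone are no guide. With nothing directly comparable, a step of compound 3 to compound 4 within the scatter is expected, a number 5.6 percentage points lower from compound 3 to compound 4 (within the scatter). Compound 4 is therefore estimated at 48%, between 28% and 68%.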

Compound 4, a percentage reported as activity, at one concentration (the size of the read-out at that concentration, not a potency): 63.6%
The estimate for compound 4 lay 15.6 percentage points below the measured number; low and high end bracket the measured number.
By their numbers in this assay, from the lowest: compound 1; then compounds 3 and 4 (each within the scatter of the next); then compound 2.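

Iodo in place of fluoro on the aromatic carbon of the 3-fluorophenoxy group gives, in this assay, a number 10 percentage points higher from compound 3 to compound 4 (within the scatter), the first halogen exchange read on one shared core. At this place, on the core of compound 3, the read-out does not separate fluoro from iodo. No data on any property of these compounds bear on this result.

On these data alone, whether the same exchange stays within the scatter on the core of compound 1 remains open. So does whether an amine, a carboxylic acid or a methoxy group on this aromatic carbon would read like the two halogens.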